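A Diethylamino Swap at the Limit of a Cytotoxicity Test

The compounds below may be only part of what the source reports. "The series", "measured", "known", "first", "only" and "open" are said of these compounds alone.

Compounds measured in a toxicity assay on MDCK cells (Canis lupus familiaris) for cytotoxicity, read by CCK-8 assay, with a stated time of 48 h; on this read-out lower numbers stand for higher toxicity in this test and higher numbers for lower toxicity in this test:
- Compound 1 `COc1ccc(C(=O)NNc2c(Br)cccc2Br)cc1`: > 100000 nM
- Compound 2 `O=C(NNc1c(Br)cccc1Br)c1ccccc1`: > 100000 nM
- Compound 3 `CN(C)c1ccc(C(=O)NNc2c(Br)cccc2Br)cc1`: > 100000 nM

Compound 3 gives > 100000 nM in this assay, and this reading is a limit of the assay, not a number. It has no separate place among the measured compounds, as the whole set shares one reading: the limit of > 100000 nM in this assay, at which 3 of the 3 values shown sit.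

Compound 4 `CCN(CC)c1ccc(C(=O)NNc2c(Br)cccc2Br)cc1` has not yet been measured. It differs from compound 3 by one change, diethylamino in place of dimethylamino on an aromatic carbon.

The closest comparison at this position is a step that the two limits leave unreadable from compound 2 to compound 3. The other two measured steps are a step that the two limits leave unreadable from compound 1 to compound 3 and a step that the two limits leave unreadable from compound 1 to compound 2. None of the three has a readable size, so the data give no measured effect of changing this group in either direction. On this basis, no step beyond the usual scatter is expected in this assay, and a further limit is the likeliest report. The expected step is a number no higher from compound 3 to compound 4 (the limit leaves the size open). For compound 4 the estimated value is 100000 nM, with an expected range from 50000 nM to 200000 nM.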

Compound 4, half-maximal cytotoxic concentration: 34000 nM
The estimate for compound 4 lay 2.9-fold (0.47 log units) above the measured number; the measured number lies below the stated range.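

Among the earlier compounds, every step at this position was unreadable, so changing the group there had no measurable effect to report. In this assay, diethylamino in place of dimethylamino, on an aromatic carbon para to a large group, gives the first readable step, an at least 2.9-fold lower number from compound 3 to compound 4 (0.46 log units; beyond the scatter), and a lower number here means higher toxicity in this test. The same holds for diethylamino in place of hydrogen, an at least 2.9-fold lower number from compound 2 to compound 4 (0.46 log units; beyond the scatter), and in place of methoxy, an at least 2.9-fold lower number from compound 1 to compound 4 (0.46 log units; beyond the scatter), but each step gives only a minimum size, since one compound of each pair rests on a limit and not on a number: the limit of > 100000 nM in this assay, at which 3 of the 4 values shown sit.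

As far as these compounds go, whether toxicity would rise further with a longer chain on the nitrogen, such as dipropylamino, or would appear with a piperidine ring or a carboxylic acid at this position remains open. From the compounds shown here alone, with only compound 4 giving a number, the true size of these steps also remains open, and so does whether the change would have the same effect on a different core.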